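The source may hold more compounds than are shown below. What is called first, only, known or untested is meant among the compounds shown, and "the series" means these compounds.

Measured so far in a functional assay on MCF7 cells (Homo sapiens) for antiproliferative activity, read by MTT assay, with a stated time of 72 h (a lower number here means a stronger inhibitor, a higher number a weaker inhibitor), for this series:
- compound 1 `Nc1nc(N)c2cc(CSC(=S)N3CCN(C4CCCCC4)CC3)ccc2n1` gives 6800 nM
- compound 2 `Cc1ccc(N2CCN(C(=S)SCc3ccc4nc(N)nc(N)c4c3)CC2)c(C)c1` gives 3120 nM

Compound 2 at 3120 nM is the lower of the two numbers. Compound 3 `Nc1nc(N)c2cc(CSC(=S)N3CCN(c4ccccc4Cl)CC3)ccc2n1` differs from it by 2-chlorophenyl in place of 2,4-dimethylphenyl on an amine nitrogen in a ring with 2-chlorophenyl in place of 2,4-dimethylphenyl. Among the compounds with values here, the only measured step at this place, a 2.2-fold lower number from compound 1 to compound 2 (0.34 log units; beyond the scatter), is modest and replaced cyclohexyl, not one phenyl group by another. Within the data shown here, no measured compound carries chlorine, so the data give no direction, and no step beyond the scatter is expected in this assay here. The estimated change is a 1.1-fold higher number from compound 2 to compound 3 (0.05 log units; within the scatter) only. Compound 3 is expected at 3500 nM with a range of 1500 nM to 8000 nM here.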

Compound 3, half-maximal inhibitory concentration: 3190 nM
Estimate against measurement, compound 3: 1.1-fold (0.04 log units) above, within the range that was stated.
By their numbers in this assay, from the lowest: compounds 2 and 3 (each within the scatter of the next); then compound 1.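

In this assay 2-chlorophenyl and 2,4-dimethylphenyl on the amine nitrogen in the ring read alike (a 1.0-fold higher number from compound 2 to compound 3 (0.01 log units; within the scatter)), so at this position the two differently substituted phenyl groups cannot be told apart. Against cyclohexyl, the second phenyl group gives a modest step (a 2.1-fold lower number from compound 1 to compound 3 (0.33 log units; beyond the scatter)) in the same direction as the first, and no listed compound goes against this. No supporting data bear on this result.

Open, going by these compounds, is how unsubstituted phenyl, benzyl or 4-methoxyphenyl would read on this nitrogen. Also open, on these data alone, is whether a small alkyl group such as methyl would read like cyclohexyl.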